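The compounds below may be only part of what the source reports. "The series", "measured", "known", "first", "only" and "open" are said of these compounds alone.

Compound 1 `CCN1CCc2c(sc(NC(=O)Nc3cccc(C)c3)c2C(N)=O)C1` is the point of departure. In a functional assay (strain AB) with Danio rerio as the target, read by microscopy, with a stated time of 1 h (a lower number here means that less compound is needed, a higher number that more compound is needed for the effect), compound 1 gives 13000 nM, the highest of the two numbers measured here. Compound 2 `CCN1CCc2c(sc(NC(=O)Nc3cccc(C#N)c3)c2C(N)=O)C1` gives 10300 nM in this assay, a change of a 1.3-fold lower number from compound 1 to compound 2 (0.10 log units; within the scatter). Compound 3 `CCN1CCc2c(sc(NC(=O)NCc3cccc(Cl)c3)c2C(N)=O)C1` reaches only a limit of this assay, > 25000 nM. The measured changes toward it were an at least 1.9-fold higher number from compound 1 to compound 3 (0.28 log units; that floor lies within the scatter) and an at least 2.4-fold higher number from compound 2 to compound 3 (0.38 log units; beyond the scatter). Compound 4 `CCN1CCc2c(sc(NC(=O)c3ccccc3)c2C(N)=O)C1` has not yet been measured; it differs from compound 1 by phenyl in place of (3-methylphenyl)amino on a carbonyl carbon. Among the measured compounds shown here, no measured step touches this side of the carbonyl carbon; the steps to compound 3 alter the group on the amide-type nitrogen and were at most modest. A step of a 1.2-fold higher number from compound 1 to compound 4 (0.09 log units; within the scatter) is therefore expected, close to the scatter. Compound 4 is estimated at 16000 nM, between 6000 nM and 40000 nM.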

Compound 4, half-maximal effective concentration: > 25000 nM
Compound 4 ended at the assay's limit (the forecaster's own chance of this, stated with the estimate: 30%); middle value at least 1.5-fold (0.19 log units) from the limit.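

Phenyl in place of (3-methylphenyl)amino on the carbonyl carbon is the first change shown on this side of the carbonyl, and it removes a hydrogen-bond donor: the result is an at least 1.9-fold higher number from compound 1 to compound 4 (0.28 log units; that floor lies within the scatter). That floor does not establish a loss beyond the scatter, yet the change gives no sign of a lower number. Compound 4 gives only a limit of the assay, not a number: the limit of > 25000 nM in this assay, at which 2 of the 4 values shown sit.

Going by these compounds, the true size of this step remains open. So does the question of whether a primary amine or a carboxylic acid on the phenyl of compound 4 would bring a measurable number in this assay.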